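Acid dissociation notes on the step to compound 4

The source may hold more compounds than are shown below. What is called first, only, known or untested is meant among the compounds shown, and "the series" means these compounds.

Measured so far:
compound 1 `CC(C)CCc1ccc2c(NCCCNCc3ccco3)ccnc2c1`: 9.47
compound 2 `COc1ccc(Oc2ccc3c(NCCCNCc4cccc(OC)c4O)ccnc3c2)cc1`: 9.28
compound 3 `COc1ccc(Oc2ccc3c(NCCCNCc4ccco4)ccnc3c2)cc1`: 9.28

In a physicochemical assay for acid dissociation, compound 3 gives 9.28, level with compound 2 at the digits shown and together with it the lowest of the three numbers; compound 1 is the furthest away. Both measured steps end at compound 3 and both stay within the scatter: a number 0.19 log units lower from compound 1 to compound 3 (within the scatter) and no change at the digits printed from compound 2 to compound 3 (within the scatter).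

Compound 4 `c1ccc(Cc2ccc3c(NCCCNCc4ccco4)ccnc3c2)cc1` awaits measurement. The change from compound 3 is benzyl in place of 4-methoxyphenoxy on an aromatic carbon. Among the compounds with values here, only one measured step alters a group on that same aromatic carbon, and it was within the scatter: a number 0.19 log units lower from compound 1 to compound 3 (within the scatter). The expected step is therefore a number 0.07 log units higher from compound 3 to compound 4 (within the scatter), nothing beyond the scatter. Compound 4 is estimated at 9.35, in a range from 9 to 9.7.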

Compound 4, acid dissociation constant: 9.47
For compound 4 the middle estimate is 0.12 log units below the measured one; the range from low to high includes it.
By their numbers in this assay, from the lowest: compounds 2, 3, 1 and 4 (each within the scatter of the next).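

In this assay, benzyl in place of 4-methoxyphenoxy on the aromatic carbon gives a number 0.19 log units higher from compound 3 to compound 4 (within the scatter), and phenyl in place of isobutyl on the saturated chain carbon gives no change at the digits printed from compound 1 to compound 4 (within the scatter). Isopentyl, 4-methoxyphenoxy and benzyl on this aromatic carbon are therefore all within the scatter of one another, whether the group holds oxygen or carbon only. Nothing available explains these numbers. On these data alone, it remains open whether an amine or a carboxylic acid on this aromatic carbon would give a step beyond the scatter.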